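A few compounds are considered here, and "the series" means these few. Any claim that something is new, unique, unknown or untested is made for them only; others in the source may bear on it.

Working notes on the series.

Compound 1 `COc1ccc(-c2nnc(SCCn3c([N+](=O)[O-])cnc3C)o2)cc1` is the reference point here. In a functional assay on MCF7 cells (Homo sapiens) for cytotoxicity, read by MTT assay, with a stated time of 48 h (a lower number here means a stronger inhibitor, a higher number a weaker inhibitor), compound 1 gives 10600 nM, the lowest of the two numbers recorded so far. Compound 2 `COc1cc(OC)cc(-c2nnc(SCCn3c([N+](=O)[O-])cnc3C)o2)c1` is its only measured companion: in this assay compound 2 gives 12800 nM, which sits within the scatter of the number for compound 1, so no order between the two can be read from these values. Within the data shown here, no step between measured compounds has been worked out for this pair.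

Compound 3 `Cc1ncc([N+](=O)[O-])n1CCSc1nnc(-c2ccco2)o1` has not yet been measured. Its difference from compound 1 is furan-2-yl in place of 4-methoxyphenyl on an aromatic carbon. The group that leaves is 4-methoxyphenyl and the group that enters is furan-2-yl, both at the same aromatic carbon of the shared core. No measured step in this series bears on this exchange, so there is no data-based reason to expect a change beyond the scatter in either direction. The step expected in this assay from compound 1 to compound 3 is a 1.4-fold higher number from compound 1 to compound 3 (0.15 log units; within the scatter), with the uncertainty skewed toward a higher number. The estimate for compound 3 in this assay is 15000 nM, with a range from 5000 nM to 45000 nM.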

Compound 3, half-maximal inhibitory concentration: 29500 nM
For compound 3 the middle estimate is 2.0-fold (0.29 log units) below the measured one, and the stated range covers the measured number.
By their numbers in this assay, from the lowest: compounds 1 and 2 (each within the scatter of the next); then compound 3.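

Among these compounds, the carbon of the shared core that carries the aromatic group is not indifferent in this assay: a 2.8-fold higher number from compound 1 to compound 3 (0.44 log units; beyond the scatter), the one step so far read between compounds that differ in a single place. Replacing 4-methoxyphenyl with furan-2-yl swaps 8 heavy atoms for 5 and a six-membered aromatic ring of carbon only for a five-membered aromatic ring with 1 hetero atom, so group size and ring type change together and this single modest step cannot separate them. No measurement at hand bears on what lies behind the step.

From the compounds shown here alone, it remains open whether an unsubstituted phenyl group at this carbon would stay near compound 1 or move toward compound 3, and whether an amine or a carboxylic acid on that phenyl ring would shift the number in either direction. A thiophen-2-yl group, with sulfur in place of the furan oxygen, and a pyridinyl group, a six-membered aromatic ring with nitrogen, would help show whether ring size or the hetero atom goes with the change.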